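Nitro to hydroxy on the aryl ketone of compound 2

The source may hold more compounds than are shown below. What is called first, only, known or untested is meant among the compounds shown, and "the series" means these compounds.

Measured compounds:
compound 1, `COc1cc(C(=O)/C=C\Nc2ccc(-c3nc4cc(OC)c(OC)c(OC)c4s3)cc2C)cc(OC)c1OC`: 11100 nM
compound 2, `COc1cc(OC)c2sc(-c3ccc(N/C=C\C(=O)c4ccc(OC)c([N+](=O)[O-])c4)c(C)c3)nc2c1`: 9390 nM
compound 3, `COc1ccc(C(=O)/C=C\Nc2ccc(-c3nc4cc(OC)c(OC)c(OC)c4s3)cc2)cc1F`: 7300 nM

Of the compounds shown here, three sharing one core have been measured in a functional assay on HeLa cells (Homo sapiens) for antiproliferative activity, read by sulforhodamine B assay, with a stated time of 48 h; a lower number here means a stronger inhibitor, a higher number a weaker inhibitor. Compound 1 gives 11100 nM, compound 2 gives 9390 nM and compound 3 gives 7300 nM. Compound 2 stands second highest of the three numbers; its nearest neighbour is compound 1, and its furthest is compound 3, yet both gaps lie within the scatter, so the three values cannot be told apart in this assay.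

The next compound, compound 4, `COc1cc(OC)c2sc(-c3ccc(N/C=C\C(=O)c4ccc(OC)c(O)c4)c(C)c3)nc2c1`, differs from compound 2 in one place:

hydroxy in place of nitro on an aromatic carbon

Among the measured compounds shown here, no step between measured compounds that differ in a single place is available, so the effect of this change has to be estimated from the three values alone. With the measured numbers all close together, a modest step toward a lower number is expected, one that may reach beyond the scatter but need not. The step from compound 2 to compound 4 is estimated as a 2.3-fold lower number from compound 2 to compound 4 (0.37 log units; beyond the scatter) in this assay. For compound 4 the expected value in this assay is 4000 nM, with a range from 1500 nM to 12000 nM.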

Compound 4, half-maximal inhibitory concentration: 16100 nM
Estimate against measurement, compound 4: 4.0-fold (0.60 log units) below; measured number outside the range, above it.
By their numbers in this assay, from the lowest: compounds 3, 2, 1 and 4 (each within the scatter of the next, the first and the last beyond it).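

In this assay, the exchange of nitro for hydroxy on the aryl ketone, at the position ortho to a methoxy group, gives a 1.7-fold higher number from compound 2 to compound 4 (0.23 log units; within the scatter), the first single-place step available in this series, and that step lies within the scatter. So although this change removes a nitro group and brings in a hydroxy group carrying a hydrogen-bond donor, turning 4-methoxy-3-nitrophenyl into 3-hydroxy-4-methoxyphenyl, the assay cannot tell compound 2 and compound 4 apart, and neither the nitro group nor the hydroxy group can be said to matter for antiproliferative activity at this position. Nothing shown here accounts for this outcome.

From the compounds shown here alone, what remains open is whether any group at this position can move the number beyond the scatter, as an amine, a carboxylic acid or a longer alkoxy chain in place of the nitro or hydroxy group might or might not do. Going by these compounds, it is also open whether the same exchange would read the same way on the trimethoxy-substituted core of compound 1 or on the core of compound 3, whose aryl ketones and cores differ from those of compound 2 in more than one place.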